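The source may hold more compounds than are shown below. What is called first, only, known or untested is meant among the compounds shown, and "the series" means these compounds.

Compound 1 `CN(C)c1ccc(C#Cc2cccc(F)c2)cc1` and compound 2 `CN(C)c1ccc(C#Cc2ccc(F)cc2)cc1` carry the same atoms joined differently; the difference between the two cores is not broken down here. In a functional assay on LS174T cells (Homo sapiens) for antiproliferative activity, with a stated time of 4 days (a lower number here means a stronger inhibitor, a higher number a weaker inhibitor), compound 1 gives only a limit, > 3000 nM. Compound 2 likewise gives only a limit, > 3000 nM. Compound 3 `CN(C)c1ccc(C#Cc2ccc(F)cc2F)cc1` gives 56 nM in this assay. The change fluoro in place of hydrogen on an aromatic carbon made an at least 53-fold lower number from compound 2 to compound 3 (1.72 log units; beyond the scatter); the size of that step is known only as a bound because of the limit of > 3000 nM in this assay, at which 2 of the 3 values shown sit. Compound 4 `CN(C)c1ccc(C#Cc2cc(F)ccc2F)cc1` has not yet been measured in this assay. It arises from compound 1 by the same kind of change, (fluoro in place of hydrogen on an aromatic carbon); the surroundings differ in that the entering fluoro is para to a fluoro group in compound 4 but meta to a fluoro group in compound 3. In this assay, within the data shown here, a step of the same direction, an at least 20-fold lower number from compound 1 to compound 4 (1.30 log units; beyond the scatter), is expected, resting on the single step from compound 2 to compound 3 and tempered by the fact that only one such step is known. Compound 4 is therefore expected to give about 150 nM, estimated between 30 nM and 1500 nM.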

Compound 4, half-maximal inhibitory concentration: 55 nM
Estimate against measurement, compound 4: 2.7-fold (0.44 log units) above, and the stated range covers the measured number.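

In this assay the entering fluoro again goes with a large step, an at least 54-fold lower number from compound 1 to compound 4 (1.73 log units; beyond the scatter), so the change points the same way on both cores shown. Set side by side, the two steps cannot be separated: the same change on two cores in this assay, an at least 53-fold lower number (1.72 log units; beyond the scatter) from compound 2 to compound 3 and an at least 54-fold lower number (1.73 log units; beyond the scatter) from compound 1 to compound 4; the limit leaves it open whether they differ. Both steps are bounds and not sizes, and only two cores are shown, so the data give neither the true size of the step on either core nor any reach to further cores: the limit of > 3000 nM in this assay, at which 2 of the 4 values shown sit.

The compounds shown leave open whether a chloro, a methoxy or a nitrile in place of the entering fluoro would go with a step of like size. Every compound shown also carries the dimethylamino group, and whether the step survives with a morpholine or a longer alkyl chain in its place stays open.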